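The compounds below may be only part of what the source reports. "The series", "measured", "known", "first", "only" and "open" are said of these compounds alone.

Measured compounds, with their partition coefficients in a physicochemical assay for lipophilicity; a lower number here means a more polar compound, a higher number a more lipophilic compound:

Compound 1, `COc1cc(O)c(C(=O)/C=C/c2cc(OC)c(OC)c(OC)c2)cc1OC`, gives 3.5.
Compound 2, `COc1ccc(C(=O)/C=C/c2cc(OC)c(OC)c(OC)c2)c(O)c1`, gives 3.49.
Compound 3, `COc1cccc(/C=C/C(=O)c2ccccc2O)c1`, gives 3.94.

Compound 2 and compound 1 differ in one place only, (methoxy in place of hydrogen on an aromatic carbon), and the step across it, a number 0.01 log units higher from compound 2 to compound 1 (within the scatter), is too small to read as a change in this assay. Compound 3 stands highest of the three measured numbers; the difference between its core and the core of compound 2 is not broken down here, and the two values simply show that compound 3 sits a good way above both compound 1 and compound 2.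

The unmeasured compound 4, `COc1cccc(/C=C/C(=O)c2ccc(OC)cc2O)c1`, is reached from compound 3 by methoxy in place of hydrogen on an aromatic carbon. Going by the values given here, this is the same kind of change as the one from compound 2 to compound 1, though the surroundings are not identical: in compound 4 the new methoxy is meta to a hydroxy group and para to a large group, whereas in compound 1 it sits ortho to a methoxy group, meta to a large group and para to a hydroxy group.

Resting on the earlier step, which in this assay was within the scatter, the study expects the step of a number 0.03 log units higher from compound 3 to compound 4 (within the scatter) to be similarly small. Compound 4 is therefore estimated at 3.97, with a likely range from 3.6 to 4.35.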

Compound 4, partition coefficient: 3.86
Compound 4: the middle estimate sits 0.11 log units above what was measured; measured number inside the range.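

In this assay, methoxy in place of hydrogen on an aromatic carbon gives a number 0.08 log units lower from compound 3 to compound 4 (within the scatter), and the same kind of change on the other core gave a number 0.01 log units higher from compound 2 to compound 1 (within the scatter), so on neither core is the step large enough to read as a change in this assay. This shows that the change carried from one core to the other in these two pairs and stayed within the scatter both times, even with the new methoxy of compound 4 meta to a hydroxy group and para to a large group, but two pairs set no rule for other cores or other places on the ring, and steps this small give no reliable direction or size for the change. Nothing in the data shown gives a reason for these results on either core.

The compounds shown leave open whether an amine, a carboxylic acid or a longer chain such as butoxy, placed on the same aromatic carbon, would also give a step within the scatter in this assay. They also leave open whether methoxy would behave in the same way on other aromatic carbons of these cores, or on a core that carries no hydroxy group.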